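The compounds below may be only part of what the source reports. "The series", "measured", "known", "first", "only" and "open" are said of these compounds alone.

In a functional assay on MDA-MB-231 cells (Homo sapiens) for cytotoxicity, read by MTT assay, with a stated time of 72 h (on this read-out lower numbers stand for stronger inhibition and higher numbers for weaker inhibition), three compounds of a shared core have been measured. Compound 1 `COc1cc2c(Oc3ccc(NC(=O)N/N=C/c4ccc(O)cc4)cc3F)ccnc2cc1OCCCN1CCCCC1` gives 790 nM. Within the data shown here, compound 2 `COc1cc2c(Oc3ccc(NC(=O)N/N=C/c4cccs4)cc3F)ccnc2cc1OCCCN1CCCCC1` gives 1260 nM, and the only single-point step among them, a 1.6-fold higher number from compound 1 to compound 2 (0.20 log units; within the scatter), stays within the scatter. Compound 3 `COc1cc2c(Oc3ccc(NC(=S)N/N=C/c4ccc(F)c(F)c4)cc3F)ccnc2cc1OCCCN1CCCCC1` gives 1400 nM, the highest of the three numbers; its nearest neighbour is compound 2 and its furthest is compound 1, and both of those gaps lie within the scatter, so nothing separates compound 3 from the others on this read-out.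

Compound 4 `COc1cc2c(Oc3ccc(NC(=S)N/N=C/c4ccc(Cl)cc4)cc3F)ccnc2cc1OCCCN1CCCCC1` is not yet measured in this assay. It differs from compound 3 in one place: 4-chlorophenyl in place of 3,4-difluorophenyl on a carbon with a double bond to nitrogen. Among the measured compounds shown here, no measured step changes a thiourea-bearing compound at this place. For the measured compounds named here, the one step that touches the same carbon, from compound 1 to compound 2, is the only guide and it was within the scatter. On that basis the exchange of one aromatic ring for another at this carbon is expected to move the number little, and compound 4 is estimated to give 1300 nM, with a range from 500 nM to 3500 nM. The step from compound 3 is therefore expected to be a 1.1-fold lower number from compound 3 to compound 4 (0.03 log units; within the scatter), a change not beyond the scatter in this assay.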

Compound 4, half-maximal inhibitory concentration: 1300 nM
Beside the measured number, compound 4's estimate shows no gap at the digits printed; low and high end bracket the measured number.
By their numbers in this assay, from the lowest: compounds 1, 2, 4 and 3 (each within the scatter of the next).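

Within the thiourea-bearing compounds, 4-chlorophenyl in place of 3,4-difluorophenyl on a carbon with a double bond to nitrogen gives, in this assay, a 1.1-fold lower number from compound 3 to compound 4 (0.03 log units; within the scatter) and so extends to a second pair the finding that one aromatic ring can replace another at this carbon without a step beyond the scatter. Larger exchanges of the whole group on a nitrogen on an aromatic ring, which alter the oxygen or sulfur of that group together with the ring, give a 1.0-fold higher number from compound 2 to compound 4 (0.01 log units; within the scatter) and a 1.6-fold higher number from compound 1 to compound 4 (0.22 log units; within the scatter), so these exchanges do not separate the compounds on this read-out either. No outside measurement bears on these results, and the compounds shown offer no explanation for them.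

The compounds shown leave open whether the carbonyl and its sulfur counterpart differ when the aromatic ring is held the same, since every such comparison here changes the ring as well. They also leave open whether this carbon tolerates a group of another kind, such as a carboxylic acid or a dimethylamino group on the phenyl ring, or a longer chain in place of the ring.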